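Does tert-Butyl Change Anything on This Shared Core?

This account rests on a few compounds, and the source may have more. Where it says the series, first, only, none or still open, it means among the compounds named here.

Of the compounds shown here, two sharing one core have been measured so far in a functional assay on HeLa cells (Homo sapiens) for inhibition, read by CCK-8 assay, with a stated time of 48 h; on this read-out lower numbers stand for stronger inhibition and higher numbers for weaker inhibition. In this test, compound 1 `COc1cc(-c2ccnc3cc(-c4ccc(Cl)cc4)nn23)cc(OC)c1OC` gives 1490 nM and compound 2 `COc1cc(-c2ccnc3cc(-c4ccc(-c5cnn(C)c5)cc4)nn23)cc(OC)c1OC` gives 1830 nM, so these two values lie within the ordinary scatter of repeated measurements. The next compound to be tested is compound 3 `COc1cc(-c2ccnc3cc(-c4ccc(C(C)(C)C)cc4)nn23)cc(OC)c1OC`. Compared with compound 2, it has tert-butyl in place of 1-methyl-1H-pyrazol-4-yl on an aromatic carbon.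

Going by the values given here, only one measured step bears on this change, because it involves the same aromatic carbon: a 1.2-fold higher number from compound 1 to compound 2 (0.09 log units; within the scatter). That exchange of chloro for 1-methyl-1H-pyrazol-4-yl stayed within the scatter. Among the compounds with values here, a single step is thin evidence, and no compound measured so far carries tert-butyl. No shift beyond the scatter is therefore expected in this assay, and neither direction is favoured. The expected step is a 1.1-fold lower number from compound 2 to compound 3 (0.06 log units; within the scatter). Compound 3 is estimated at 1600 nM, with an expected range from 700 nM to 3600 nM.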

Compound 3, half-maximal inhibitory concentration: > 10000 nM
Compound 3: a limit, no number (the forecaster's own chance of this, stated with the estimate: 5%); middle value at least 6.2-fold (0.79 log units) away from the limit.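

Going by these compounds alone, the step to tert-butyl is the first change at this aromatic carbon to lie beyond the scatter, and it goes towards weaker inhibition: replacing 1-methyl-1H-pyrazol-4-yl gives an at least 5.4-fold higher number from compound 2 to compound 3 (0.73 log units; beyond the scatter), and replacing chloro gives an at least 6.7-fold higher number from compound 1 to compound 3 (0.82 log units; beyond the scatter). In this assay, this position therefore does respond to the group it carries, which the exchange of chloro for 1-methyl-1H-pyrazol-4-yl, a 1.2-fold higher number from compound 1 to compound 2 (0.09 log units; within the scatter), could not show. The result for compound 3 is a limit and not a number, so both new steps give only a minimum size: the limit of > 10000 nM in this assay, at which 1 of the 3 values shown sits.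

The compounds shown do not reveal what separates tert-butyl from the other two groups, since chloro has no ring either and yet compound 1 lies within the scatter of compound 2, whose 1-methyl-1H-pyrazol-4-yl group does have one. An amine, a carboxylic acid or a straight butyl chain on this same aromatic carbon would help to show whether the loss of inhibition belongs to tert-butyl alone or extends to a wider set of groups.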